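Replacing methylsulfonyl on oxygen in compound 3

This account rests on a few compounds, and the source may have more. Where it says the series, first, only, none or still open, it means among the compounds named here.

In a functional assay on HeLa cells (Homo sapiens) for cytotoxicity (a lower number here means a stronger inhibitor, a higher number a weaker inhibitor), compound 3 (`CS(=O)(=O)Oc1ccc2c(c1)C(=O)C=CC2=O`) gives 17700 nM and sits at the upper end of the three numbers, level with compound 1 (`Cc1ccc(S(=O)(=O)Oc2ccc3c(c2)C(=O)C=CC3=O)cc1`) at 15100 nM in the same range. Compound 2 (`CS(=O)(=O)OC1=CC(=O)c2ccccc2C1=O`) gives 7610 nM and lies lower than compound 3 by more than the scatter. Compound 4 (`O=C1C=CC(=O)c2cc(Oc3cccs3)ccc21`) carries thiophen-2-yl in place of methylsulfonyl on an oxygen on an aromatic ring. For the measured compounds named here, the only measured step nearby is a 1.2-fold higher number from compound 1 to compound 3 (0.07 log units; within the scatter) and it changed only the group on the sulfonyl sulfur, so it guides weakly. No shift beyond the scatter is expected, in either direction. The expected change is a 1.5-fold lower number from compound 3 to compound 4 (0.17 log units; within the scatter) with wide uncertainty. Compound 4 is estimated at 12000 nM within a range of 4000 nM to 35000 nM for now.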

Compound 4, half-maximal inhibitory concentration: 8860 nM
The estimate for compound 4 lay 1.4-fold (0.13 log units) above the measured number, within the range that was stated.
By their numbers in this assay, from the lowest: compounds 2, 4, 1 and 3 (each within the scatter of the next, the first and the last beyond it).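

In this assay the exchange of methylsulfonyl for thiophen-2-yl on the oxygen gives a 2.0-fold lower number from compound 3 to compound 4 (0.30 log units; within the scatter) and stays inside the scatter. Compounds 1 and 3 both kept a sulfonyl on this oxygen, whereas compound 4 shows that this position accepts a five-membered aromatic ring with no sulfonyl and no clear shift in the number. No available data explain this result.

The compounds shown leave open how an amine, a carboxylic acid or a longer chain on this oxygen would read. They also leave open whether thiophen-2-yl itself contributes anything specific here.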